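Nitro in place of trifluoromethoxy on a piperazine urea

This account rests on a few compounds, and the source may have more. Where it says the series, first, only, none or still open, it means among the compounds named here.

Measured compounds:
compound 1 `CC(C)(C)c1ccc(NC(=S)N2CCN(c3ncccc3C(F)(F)F)CC2)cc1`: 246 nM
compound 2 `O=C(Nc1ccc(OC(F)(F)F)cc1)N1CCN(c2ncccc2Cl)CC1`: 93.2 nM

In a functional assay on HEK293 cells for antagonist activity at transient receptor potential cation channel subfamily V member 1 (Rattus norvegicus) (a lower number here means a stronger inhibitor, a higher number a weaker inhibitor), compound 2 gives 93.2 nM, the lower of the two numbers; compound 1 `CC(C)(C)c1ccc(NC(=S)N2CCN(c3ncccc3C(F)(F)F)CC2)cc1` gives 246 nM, a gap beyond the usual scatter. Compound 3 `O=C(Nc1ccc([N+](=O)[O-])cc1)N1CCN(c2ncccc2Cl)CC1` keeps the core of compound 2 and changes one group: nitro in place of trifluoromethoxy on an aromatic carbon. Among the measured compounds shown here, no measured pair shows this change, so the step from compound 2 to compound 3 is a guess. The expected step is a moderate move toward weaker inhibition, a 3.2-fold higher number from compound 2 to compound 3 (0.51 log units; beyond the scatter), likely beyond the scatter. Compound 3 is therefore estimated at 300 nM, with a plausible range from 80 nM to 1200 nM.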

Compound 3, half-maximal inhibitory concentration: 1110 nM
Compound 3: the middle estimate sits 3.7-fold (0.57 log units) below what was measured; measured number inside the range.
By their numbers in this assay, from the lowest: compound 2; then compound 1; then compound 3.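

In this assay, the group on the aromatic carbon para to a large group clearly matters: with the rest of the molecule unchanged, nitro in place of trifluoromethoxy gives a 12-fold higher number from compound 2 to compound 3 (1.08 log units; beyond the scatter). This single-group change isolates that position, which compound 1 and compound 2 could not do, since they differ in several places. Nothing measured here explains the size of this step. Going by these compounds, whether an amine or a nitrile at this position would fall nearer compound 2 or compound 3 remains open, as does whether the same change would have a similar effect on the core of compound 1.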